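Working notes: from compound 2 to compound 3

The source may report more compounds than this note shows. Statements on the series, on what has been measured and on what is new or still open speak of the compounds shown alone.

- compound 1 `O=C1OC[C@H](Cc2ccccc2)[C@H]1Cc1ccccc1O` gives 83000 nM as measured
- compound 2 `O=C1OC[C@H](Cc2cccc(O)c2)[C@H]1Cc1ccc(Cl)c(Cl)c1` gives 48000 nM as measured

In a functional assay on HL-60 cells (Homo sapiens) for cytotoxicity, read by WST assay, with a stated time of 48 h (a lower number here means that less compound is needed, a higher number that more compound is needed for the effect), compound 2 stands at 48000 nM and compound 1 at 83000 nM so the two values lie within the usual scatter of each other. The two structures differ in more than one place, which means that no single change has yet been measured in this series.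

Compound 3 `Cc1ccc(C[C@H]2COC(=O)[C@@H]2Cc2ccc(Cl)c(Cl)c2)cc1` has not been measured. Its change against compound 2 reads 4-methylphenyl in place of 3-hydroxyphenyl on a saturated chain carbon bound to a saturated ring carbon and puts 4-methylphenyl in place of 3-hydroxyphenyl on a saturated chain carbon bound to a saturated ring carbon.

No measurement isolates this replacement, so no step beyond the scatter is expected in this assay and no direction can be favoured with confidence. Going by the values given here, the only guide is that compound 1 at 83000 nM and compound 2 at 48000 nM remain within the scatter despite their differing structures. The expected change is a 1.2-fold lower number from compound 2 to compound 3 (0.08 log units; within the scatter) and it is estimated to stay small. For compound 3 the estimated value is 40000 nM with an expected range from 15000 nM to 100000 nM in this measurement.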

Compound 3, half-maximal effective concentration: 19000 nM
The estimate for compound 3 lay 2.1-fold (0.32 log units) above the measured number, and the stated range covers the measured number.
By their numbers in this assay, from the lowest: compound 3; then compounds 2 and 1 (each within the scatter of the next).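

In this assay the series now has its first reading of a change in one place, a 2.5-fold lower number from compound 2 to compound 3 (0.40 log units; beyond the scatter), with 4-methylphenyl in place of 3-hydroxyphenyl on a saturated chain carbon bound to a saturated ring carbon. Going by these compounds alone, the earlier pair differed in more than one place, so this is the first sign that the group at this place can shift the number by more than the scatter, although the step is modest and rests on a single pair. No measured property bears on this result, so the step stands as an observation without an assigned cause.

The step swaps two features at once, since the hydroxy group leaves and a methyl group enters at a different ring location, so its size cannot be divided between the two. On the remainder of compound 3, unsubstituted phenyl, 3-methylphenyl and 4-hydroxyphenyl would separate these contributions, while 4-ethylphenyl or an aminomethyl group on the phenyl ring would show whether the trend extends beyond methyl.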